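Changing the Amide Tail of a Cholesterol Transporter Ligand

A few compounds are considered here, and "the series" means these few. Any claim that something is new, unique, unknown or untested is made for them only; others in the source may bear on it.

Measured compounds:
Compound 1, `CCOC(=O)C1CCN(C(=O)CN2CN(c3ccccc3)C3(CCN(C(=O)c4ccc(C5CCCCC5)cc4)CC3)C2=O)CC1`, gives 900 nM.
Compound 2, `CC(C)(C)c1ccc(C(=O)N2CCC3(CC2)C(=O)N(CC(=O)NCCC(=O)O)CN3c2ccccc2)cc1`, gives 11400 nM.
Compound 3, `CCOC(=O)C1CCN(C(=O)CN2CN(c3ccccc3)C3(CCN(C(=O)c4ccc(C(C)(C)C)cc4)CC3)C2=O)CC1`, gives 3100 nM.

All three share one core and were tested in an assay on HEK293 cells for displacement of a labelled ligand from NPC1-like intracellular cholesterol transporter 1 (Homo sapiens); a lower number here means a stronger inhibitor, a higher number a weaker inhibitor. Compound 1 has the lowest number of the three; its nearest neighbour is compound 3, with a 3.4-fold higher number from compound 1 to compound 3 (0.54 log units; beyond the scatter), and its furthest is compound 2. The unmeasured compound 4, `O=C(CN1CN(c2ccccc2)C2(CCN(C(=O)c3ccc(C4CCCCC4)cc3)CC2)C1=O)NCO`, differs from compound 1 at one place: (hydroxymethyl)amino in place of 4-(ethoxycarbonyl)piperidin-1-yl on a carbonyl carbon.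

One measured step speaks to this kind of change. Going a 3.7-fold lower number from compound 2 to compound 3 (0.57 log units; beyond the scatter) exchanged a small, open-chain amide substituent for the 4-(ethoxycarbonyl)piperidin-1-yl group on the same carbonyl carbon, and the number fell. Compound 4 runs the other way: the 4-(ethoxycarbonyl)piperidin-1-yl group leaves and a small (hydroxymethyl)amino group enters. A rise in the number of a similar, modest size is therefore expected for compound 4 in this assay, rather than a change within the scatter. The expected step is a 3.3-fold higher number from compound 1 to compound 4 (0.52 log units; beyond the scatter), and compound 4 is estimated at 3000 nM, with a likely range from 1200 nM to 9000 nM.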

Compound 4, half-maximal inhibitory concentration: 8300 nM
The estimate for compound 4 lay 2.8-fold (0.44 log units) below the measured number; measured number inside the range.
By their numbers in this assay, from the lowest: compound 1; then compound 3; then compounds 4 and 2 (each within the scatter of the next).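

In this assay, the step of a 9.2-fold higher number from compound 1 to compound 4 (0.96 log units; beyond the scatter) shows that the group on this carbonyl carbon also matters when cyclohexyl sits on the aromatic carbon, whereas the earlier step at this place, a 3.7-fold lower number from compound 2 to compound 3 (0.57 log units; beyond the scatter), came from compounds carrying tert-butyl there. In both pairs, the compound holding 4-(ethoxycarbonyl)piperidin-1-yl has the lower number, and none of the four compounds goes against this, although the two pairs differ in both the replacing group and the group on the aromatic carbon. Compound 4 also shows that the replacing group need not contain a carboxylic acid, as in (2-carboxyethyl)amino, for the number to rise: (hydroxymethyl)amino, with no net charge, goes the same way.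

This change removes a ring and an ethyl ester together, with 11 heavy atoms leaving and 3 entering, so telling which part counts would take a plain piperidin-1-yl group, which keeps the ring without the ester, or an open-chain amine ending in an ethyl ester, which keeps the ester without the ring. Nothing measured here explains why the number rises with this change.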